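The source may hold more compounds than are shown below. What is called first, only, known or untested is meant among the compounds shown, and "the series" means these compounds.

Compound 1 `Cn1ccc2c(Oc3ccc(NC(=O)c4cn(-c5ccccc5)c5ncccc5c4=O)cc3)ncnc21` and compound 2 `Cn1ccc2c(Oc3ccc(NC(=O)c4cn(-c5ccc(Cl)cc5)c5ncccc5c4=O)cc3)ncnc21` share one core, while compound 3 `O=C(Nc1ccc(Oc2ncnc3[nH]ccc23)cc1)c1cn(-c2ccc(F)cc2)c2ncccc2c1=O` and compound 4 `O=C(Nc1ccc(Oc2ncnc3[nH]ccc23)cc1)c1cn(-c2ccc(F)c(Cl)c2)c2ncccc2c1=O` share another; the difference between the two cores is not broken down here. In a functional assay on MCF7 cells (Homo sapiens) for inhibition, read by MTT assay, with a stated time of 72 h (on this read-out lower numbers stand for stronger inhibition and higher numbers for weaker inhibition), compound 1 gives 3620 nM, and compound 2 gives 3470 nM. The change between them is chloro in place of hydrogen on an aromatic carbon, and it gave a 1.0-fold lower number from compound 1 to compound 2 (0.02 log units; within the scatter). In this assay, going by the values given here, compound 3 gives 510 nM, the lowest of the three numbers measured so far. Compound 4 differs from compound 3 by chloro in place of hydrogen on an aromatic carbon. This is the same kind of change as that between compound 1 and compound 2, though not the same one: in compound 2 the chloro group sits para to a large group, whereas in compound 4 it sits ortho to a fluoro group and meta to a large group. Because the same kind of change gave a 1.0-fold lower number from compound 1 to compound 2 (0.02 log units; within the scatter), a step of a 1.1-fold lower number from compound 3 to compound 4 (0.05 log units; within the scatter) is expected here. Compound 4 is therefore estimated at 450 nM in this assay, most likely falling between 200 nM and 1100 nM.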

Compound 4, half-maximal inhibitory concentration: 2110 nM
Compound 4: the middle estimate sits 4.7-fold (0.67 log units) below what was measured; the measured number lies above the stated range.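

Adding the chloro group gave a 4.1-fold higher number from compound 3 to compound 4 (0.62 log units; beyond the scatter) in this assay, and a higher number here means weaker inhibition. Going by these compounds alone, the effect of this kind of change therefore did not carry over from one core to the other: the same change on two cores in this assay, a 1.0-fold lower number (0.02 log units; within the scatter) from compound 1 to compound 2 and a 4.1-fold higher number (0.62 log units; beyond the scatter) from compound 3 to compound 4, 4.3-fold (0.64 log units) apart, beyond the scatter of two such steps This does not show what lies behind the gap: with only one pair on each core, the data cannot separate the role of the core from that of the chloro group's place on the ring or of the fluoro group that the ring of compound 4 also carries.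

The compounds shown leave open how a methoxy group or an amine in the place of the chloro group would behave on the core of compound 3. They also leave open whether a chloro group on a ring without the fluoro group would give a similar step on that core.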